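The compounds below may be only part of what the source reports. "The series", "measured", "known", "first", "only" and "open" are said of these compounds alone.

Compound 1 `O=c1[nH]cc(S(=O)(=O)Nc2ccccc2-c2cn(-c3ccccc3F)nn2)c(=O)[nH]1`: 15300 nM
Compound 2 `Cc1ccccc1-n1cc(-c2cccc(NS(=O)(=O)c3c[nH]c(=O)[nH]c3=O)c2)nn1`: 6230 nM

In a functional assay on OVCAR-3 cells (Homo sapiens) for antiproliferative activity, read by MTT assay, with a stated time of 24 h (a lower number here means a stronger inhibitor, a higher number a weaker inhibitor), compound 2 gives 6230 nM, the lower of the two numbers, and its gap to compound 1 lies beyond the usual scatter. Compound 3 `O=c1[nH]cc(S(=O)(=O)Nc2cccc(-c3cn(-c4ccccc4Cl)nn3)c2)c(=O)[nH]1` differs from compound 2 in one place: chloro in place of methyl on an aromatic carbon. For the measured compounds named here, no measured pair shows this swap, so no change beyond the scatter is expected in this assay, in either direction. The expected change is small: a 1.0-fold lower number from compound 2 to compound 3 (0.02 log units; within the scatter). The estimate for compound 3 is 6000 nM, with an expected range of 2500 nM to 14000 nM.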

Compound 3, half-maximal inhibitory concentration: 5370 nM
The estimate for compound 3 lay 1.1-fold (0.05 log units) above the measured number; measured number inside the range.
By their numbers in this assay, from the lowest: compounds 3 and 2 (each within the scatter of the next); then compound 1.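

In this assay, replacing 2-methylphenyl with 2-chlorophenyl gives a 1.2-fold lower number from compound 2 to compound 3 (0.06 log units; within the scatter), so at this position methyl and chloro read alike. For the compounds shown here, compounds 1 and 2 differ in more than one place, so only this pair isolates a single group on that aromatic carbon. Nothing available here offers a reason for the match.

Going by these compounds, whether a larger or different group, such as methoxy, an amine or a carboxylic acid, would also leave the number in place remains open. So does whether the same swap would read alike on the core of compound 1.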